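Sulfonyl aryl variation on a shared quinoline-like core, working notes

A few compounds are considered here, and "the series" means these few. Any claim that something is new, unique, unknown or untested is made for them only; others in the source may bear on it.

Measured so far:
compound 1 `Cc1ccc2ncc(S(=O)(=O)c3ccc(C)c(Cl)c3)c(N3CCC(C)CC3)c2c1` gives 91%
compound 2 `Cc1ccc2ncc(S(=O)(=O)c3cc(F)cc(F)c3)c(N3CCC(C)CC3)c2c1` gives 72%

In an assay on isolated protein for displacement of a labelled ligand from metabotropic glutamate receptor 5 (Homo sapiens), with a stated time of 60 min, tested at 1 uM (a higher number here means more inhibition at the concentration tested (going by the name of the read-out), a lower number less inhibition), compound 2 stands lowest of the two numbers; its nearest neighbour is compound 1, which gives 91%. Going by the values given here, the one measured step on the sulfonyl sulfur, a number 19 percentage points lower from compound 1 to compound 2 (beyond the scatter), came with 3,5-difluorophenyl in place of 3-chloro-4-methylphenyl.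

Compound 3 `COc1cccc(S(=O)(=O)c2cnc3ccc(C)cc3c2N2CCC(C)CC2)c1` is not yet measured. It differs from compound 2 by 3-methoxyphenyl in place of 3,5-difluorophenyl on a sulfonyl sulfur. Among the compounds with values here, the only step that bears on it is a number 19 percentage points lower from compound 1 to compound 2 (beyond the scatter), which shows that a swap of the aryl group on the sulfonyl sulfur can move this assay by a modest amount. Within the data shown here, no measured pair shows 3-methoxyphenyl itself, so the direction is open; a change of modest size in either direction, or none beyond the scatter, is possible.

Compound 3 is expected to give 78%, range 55% to 95%, in this assay. The estimated step is a number 6 percentage points higher from compound 2 to compound 3 (within the scatter).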

Compound 3, a percentage reported as inhibition, at one concentration (the size of the read-out at that concentration, not a potency): 96%
For compound 3 the middle estimate is 18 percentage points below the measured one; the whole stated range lies below it.
By their numbers in this assay, from the lowest: compound 2; then compounds 1 and 3 (each within the scatter of the next).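

In this assay the swap on the sulfonyl sulfur gives a number 24 percentage points higher from compound 2 to compound 3 (beyond the scatter) and so settles the direction for 3-methoxyphenyl, which the earlier pair left open. Set against 3-chloro-4-methylphenyl, the same group gives a number 5 percentage points higher from compound 1 to compound 3 (within the scatter) and the two differently substituted aryl groups sit level, so among these three compounds only the 3,5-difluorophenyl of compound 2 stands apart. Nothing available here accounts for this difference.

The compounds shown leave open whether the two fluorines or some other feature of that aryl group set compound 2 apart, since no pair varies one substituent alone. Also open, as far as these compounds go, is how an amine, a carboxylic acid or an ethoxy group on the aryl ring would read, and, with only a single tested concentration, how compound 1 and compound 3 compare in potency.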